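This account rests on a few compounds, and the source may have more. Where it says the series, first, only, none or still open, it means among the compounds named here.

In a functional assay on MCF7 cells (Homo sapiens) for cytotoxicity, read by MTT assay, with a stated time of 48 h (on this read-out higher numbers stand for weaker inhibition and lower numbers for stronger inhibition), compound 1 `COc1ccc(NC(=S)N/N=C\c2ccnc3ccccc23)cc1` gives 990 nM, compound 2 `Fc1ccc(NC(=S)N/N=C\c2ccnc3ccccc23)cc1` gives 1100 nM and compound 3 `S=C(N/N=C\c1ccnc2ccccc12)Nc1ccc(Cl)cc1` gives 1070 nM. Compound 3 thus stands within the scatter of both other compounds, and the three cannot be ranked. Compound 4 `S=C(N/N=C\c1ccnc2ccccc12)Nc1ccc(Br)cc1` differs from compound 3 by a single exchange, bromo in place of chloro on an aromatic carbon, para to a large group. Going by the values given here, three measured steps bear on this change: a 1.1-fold higher number from compound 1 to compound 2 (0.05 log units; within the scatter), a 1.1-fold higher number from compound 1 to compound 3 (0.03 log units; within the scatter) and the closest analogue, a 1.0-fold lower number from compound 2 to compound 3 (0.01 log units; within the scatter). All three lie within the scatter, so no step beyond the scatter is expected in this assay. The expected step is a 1.0-fold higher number from compound 3 to compound 4 (0.00 log units; within the scatter). Compound 4 is estimated at 1080 nM, with an expected range from 650 nM to 1800 nM.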

Compound 4, half-maximal inhibitory concentration: 990 nM
The estimate for compound 4 lay 1.1-fold (0.04 log units) above the measured number; measured number inside the range.
By their numbers in this assay, from the lowest: compounds 1, 4, 3 and 2 (each within the scatter of the next).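

With bromo added, the 4-chlorophenyl to 4-bromophenyl exchange in this assay gives a 1.1-fold lower number from compound 3 to compound 4 (0.03 log units; within the scatter), while the exchange from fluoro gives a 1.1-fold lower number from compound 2 to compound 4 (0.05 log units; within the scatter) and the exchange from methoxy gives no change at the digits printed from compound 1 to compound 4 (within the scatter). Four different groups on this aromatic carbon, para to a large group, therefore cannot be told apart on this read-out, and bromo is no exception among the listed compounds. No measured evidence is available to account for this result. Going by these compounds, whether an amine or a carboxylic acid at this place would leave the read-out within the scatter remains open, as do exchanges elsewhere on the shared core.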